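Replacing the naphthalene on the carbonyl

This account rests on a few compounds, and the source may have more. Where it says the series, first, only, none or still open, it means among the compounds named here.

In a functional assay on CCRF-CEM cells (Homo sapiens) for inhibition (on this read-out higher numbers stand for weaker inhibition and lower numbers for stronger inhibition), compound 1 (`Cn1cc(C#N)c2ccc(Nc3ncc(-c4cccc(CNC(=O)c5ccccc5)c4)o3)cc21`) gives 5300 nM and compound 2 (`Cn1cc(C#N)c2ccc(Nc3ncc(-c4cccc(CNC(=O)c5ccc6ccccc6c5)c4)o3)cc21`) gives 4400 nM, so the two stand within the scatter of each other. Compound 3 (`Cn1cc(C#N)c2ccc(Nc3ncc(-c4cccc(CNC(=O)OC5CCOC5)c4)o3)cc21`) has not yet been measured. It keeps the core of compound 2 and carries (oxolan-3-yl)oxy in place of naphthalen-2-yl on a carbonyl carbon. For the measured compounds named here, one measured step bears on this position: a 1.2-fold lower number from compound 1 to compound 2 (0.08 log units; within the scatter). Going by the values given here, that step only exchanged one aromatic group for another, and no measured compound shows a non-aromatic ring or an oxy link here, so the support is thin. Among the compounds with values here, with only that small step as a guide, no shift beyond the scatter is expected in this assay, and the expected step is a 1.1-fold higher number from compound 2 to compound 3 (0.06 log units; within the scatter). For compound 3 the estimated value is 5000 nM, with an expected range of 1800 nM to 14000 nM.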

Compound 3, half-maximal inhibitory concentration: > 10000 nM
Compound 3: a limit, no number; the forecaster's own chance of this, stated with the estimate: 15%; middle value at least 2.0-fold (0.30 log units) from the limit.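

Compound 3 reads as a limit of the assay and not a number: the limit of > 10000 nM in this assay, at which 1 of the 3 values shown sits. In this assay, for the compounds shown here, the exchange of naphthalen-2-yl for (oxolan-3-yl)oxy gives an at least 2.2-fold higher number from compound 2 to compound 3 (0.35 log units; beyond the scatter), the first step at this position that lies beyond the scatter, so the position does not tolerate every group on the carbonyl carbon, unlike the exchange of one aromatic group for another. Measured from the phenyl group, the same kind of exchange gives an at least 1.8-fold higher number from compound 1 to compound 3 (0.27 log units; that floor lies within the scatter), so that floor alone does not separate the two compounds.

In compound 3 the aromatic rings leave and the oxy link enters together, and the compounds shown do not tell these two changes apart. On these data alone, a benzyloxy group or a cyclohexyl group on the carbonyl carbon would address that question, and how an amine would read also remains open.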